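The source may hold more compounds than are shown below. What is called first, only, known or untested is meant among the compounds shown, and "the series" means these compounds.

Working notes on a small set of diaryl ethers tested in an assay on HEK293 cells for inhibition of Toll-like receptor 8 (Homo sapiens), with a stated time of 16 h; on this read-out higher numbers stand for weaker inhibition and lower numbers for stronger inhibition. Compound 1 `N#Cc1c(Cl)cccc1Oc1ccc(-c2nnco2)cc1` gives 1400 nM in this assay. Compound 2 `Fc1cccc(Cl)c1CNc1ccc(Oc2cc(C(F)(F)F)cc(C(F)(F)F)c2)cc1` in this assay returns only a limit, > 50000 nM. Of the two readings in hand, compound 2 sits at that limit, as recorded in the limit of > 50000 nM in this assay, at which 1 of the 2 values shown sits. Compound 3 `O=C(Nc1ccc(Oc2cc(C(F)(F)F)cc(C(F)(F)F)c2)cc1)c1ccccc1F` has not yet been run in this assay. It differs from compound 2 by (2-fluorophenyl)carbonyl in place of 2-chloro-6-fluorobenzyl on a nitrogen on an aromatic ring. Among the compounds with values here, no measured pair differing in a single place is available, so no step size can be read from the data; the exchange of a benzyl for a carbonyl on that nitrogen is expected to move the reading in this assay downward from the limit at most modestly, and it may remain beyond the scatter only marginally, or not at all. For compound 3 an estimate of 25000 nM is made, within a range of 5000 nM to 50000 nM. This corresponds to an expected step of an at least 2.0-fold lower number from compound 2 to compound 3 (0.30 log units; that floor lies within the scatter).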

Compound 3, half-maximal inhibitory concentration: 3000 nM
For compound 3 the middle estimate is 8.3-fold (0.92 log units) above the measured one, outside the stated range (below it).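

On this nitrogen on an aromatic ring, the group carried decides whether this assay returns a number at all: (2-fluorophenyl)carbonyl in place of 2-chloro-6-fluorobenzyl gives an at least 16-fold lower number from compound 2 to compound 3 (1.22 log units; beyond the scatter). Within the data shown here, this is the first single-place comparison, and it shows that the core shared by compound 2 and compound 3 can give a measurable reading with the right group on that nitrogen. The true size of the step stays unknown, and only its floor can be stated, because compound 2 is recorded as a limit rather than a number: the limit of > 50000 nM in this assay, at which 1 of the 3 values shown sits.

The change brings in the carbonyl and removes the chlorine together, and the compounds shown do not separate these two parts. From the compounds shown here alone, whether a (2-chloro-6-fluorophenyl)carbonyl or a sulfonyl on that nitrogen would hold the reading of compound 3 remains open.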